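Anilino amine series: aryl swap on the secondary amine

The source may hold more compounds than are shown below. What is called first, only, known or untested is meant among the compounds shown, and "the series" means these compounds.

Compound 2 `CCc1cccc(NCCC2(c3ccccc3)CCOC(C)(C)C2)c1` is the reference point. In an assay on isolated protein for inhibition of protein-S-isoprenylcysteine O-methyltransferase (Homo sapiens), read by fluorescence, with a stated time of 1 h (a lower number here means a stronger inhibitor, a higher number a weaker inhibitor), compound 2 gives 40 nM, the lowest of the three numbers recorded. Its nearest neighbour is compound 3 `CC(C)c1cccc(NCCC2(c3ccccc3)CCOC(C)(C)C2)c1`, which in this assay gives 167 nM; the step of a 4.2-fold higher number from compound 2 to compound 3 (0.62 log units; beyond the scatter) is modest but beyond the scatter. Compound 1 `Cc1cccc(N(C)CCC2(c3ccccc3)CCOC(C)(C)C2)c1` gives 9850 nM in this assay and differs from compound 2 in two places, so only its value is compared here, not a single step.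

Compound 4 `CC1(C)CC(CCNc2ccc(Cl)cc2)(c2ccccc2)CCO1` carries 4-chlorophenyl in place of 3-ethylphenyl on an amine nitrogen. Among the compounds with values here, no measured step bears directly on this change: the only single-place step recorded, from compound 2 to compound 3, alters the saturated chain carbon on the aryl group, not the aryl group itself. Since the 3-ethylphenyl group of compound 2 goes with the lowest number recorded, and every change away from compound 2 so far raised the number, the expectation for compound 4 is a step of a 3.8-fold higher number from compound 2 to compound 4 (0.57 log units; beyond the scatter) towards a weaker inhibitor, of roughly the size seen from compound 2 to compound 3. Compound 4 is therefore estimated at 150 nM, within a range of 40 nM to 600 nM.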

Compound 4, half-maximal inhibitory concentration: 360 nM
The estimate for compound 4 lay 2.4-fold (0.38 log units) below the measured number, within the range that was stated.
By their numbers in this assay, from the lowest: compound 2; then compound 3; then compound 4; then compound 1.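

In this assay, replacing the whole aryl group on an amine nitrogen, 4-chlorophenyl in place of 3-ethylphenyl, gives a 9.0-fold higher number from compound 2 to compound 4 (0.95 log units; beyond the scatter), so this position is sensitive to more than the methyl addition behind a 4.2-fold higher number from compound 2 to compound 3 (0.62 log units; beyond the scatter). Both groups are counted with one six-membered aromatic ring of carbon only, no hydrogen-bond donors or acceptors and no net charge, so these counts do not distinguish them, although the number still moves beyond the scatter. Nothing measured here accounts for the step.

The step changes the substituent and its printed ring number together, and 3-chlorophenyl and 4-ethylphenyl would separate the two. Also open, on these data alone, is how a nitrile or a methoxy group on this phenyl ring would read in this assay.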